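Phenyl for pyridin-2-yl on the shared core

The source may hold more compounds than are shown below. What is called first, only, known or untested is meant among the compounds shown, and "the series" means these compounds.

Compound 2 `Oc1cccc(-c2cc(-c3cccc(Cl)c3)nc(-c3ccccn3)c2)c1` stands without a number: in a functional assay on HCT-15 cells (Homo sapiens) for cytotoxicity, read by CCK-8 assay and cell counting, with a stated time of 2 days (on this read-out lower numbers stand for stronger inhibition and higher numbers for weaker inhibition), compound 2 is recorded as "not determined" (no result reported), and compound 3 `Oc1cccc(-c2cc(-c3ccccn3)nc(-c3ccccc3Cl)c2)c1` likewise gives only "not determined" (no result reported). The one figure available comes from compound 1 `Oc1ccc(-c2cc(-c3cccc(Cl)c3)nc(-c3ccccn3)c2)cc1`, which in this assay gives 28200 nM. Compound 4 `Oc1cccc(-c2cc(-c3ccccc3)nc(-c3cccc(Cl)c3)c2)c1` differs from compound 2 by a single exchange: phenyl in place of pyridin-2-yl on an aromatic carbon. Going by the values given here, no measured pair shows what this exchange does, and compound 2 itself offers no baseline, so the direction of the step is unknown; one would expect a step in this assay not clearly beyond the scatter, in either direction. Guided only by compound 1 and its 28200 nM, compound 4 is estimated at 30000 nM, with a plausible range from 8000 nM to 100000 nM.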

Compound 4, half-maximal inhibitory concentration: 2550 nM
Estimate against measurement, compound 4: 12-fold (1.07 log units) above; the measured number lies below the stated range.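

In this assay, going by these compounds alone, compound 2 has no single number, so no step to compound 4 can be read. The compounds shown leave open what phenyl in place of pyridin-2-yl does on this core. No evidence shown bears on this result.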